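Working notes: one group exchange on the chain carbon

The source may report more compounds than this note shows. Statements on the series, on what has been measured and on what is new or still open speak of the compounds shown alone.

- Compound 1 `CC(C)C(/C=C1\NC(=O)NC1=O)c1ccc(-c2ccc3cccc(F)c3c2)[nH]c1=O`: 7500 nM
- Compound 2 `Cc1cc(C(/C=C2\OC(=O)NC2=O)C(C)C)c(=O)[nH]c1-c1ccc2cccc(F)c2c1`: 39400 nM

In a physicochemical assay for solubility, measured as kinetic solubility, at pH 2 (on this read-out lower numbers stand for lower solubility and higher numbers for higher solubility), compound 1 gives 7500 nM, the lower of the two numbers. Compound 3 `C/C(=C1/OC(=O)NC1=O)C(c1ccc(-c2ccc3cccc(F)c3c2)[nH]c1=O)C(C)C` is still unmeasured. Relative to compound 1 it shows this change: a group of 9 heavy atoms (5 carbon, 1 nitrogen, 3 oxygen; one five-membered non-aromatic ring with 2 hetero atoms) in place of a group of 8 heavy atoms (4 carbon, 2 nitrogen, 2 oxygen; one five-membered non-aromatic ring with 2 hetero atoms), on a saturated chain carbon bound to an aromatic carbon and a saturated chain carbon. Among the measured compounds shown here, no step between measured compounds is available as a guide. Compound 2 stands higher at 39400 nM, but it differs from compound 1 in more than one place, so it offers only loose support. The expected change is upward and beyond the scatter: a 2.4-fold higher number from compound 1 to compound 3 (0.38 log units; beyond the scatter). For compound 3 the estimated value is 18000 nM, with an expected range of 6000 nM to 50000 nM.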

Compound 3, solubility: 12700 nM
The estimate for compound 3 lay 1.4-fold (0.15 log units) above the measured number, and the stated range covers the measured number.
By their numbers in this assay, from the lowest: compounds 1 and 3 (each within the scatter of the next); then compound 2.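

On the saturated chain carbon bound to an aromatic carbon and a saturated chain carbon, exchanging the group of 8 heavy atoms for the group of 9 heavy atoms gives, in this assay, a 1.7-fold higher number from compound 1 to compound 3 (0.23 log units; within the scatter). Among the compounds shown here, this is the first single-place step, and it leaves compound 1 and compound 3 indistinguishable on this read-out, even though hydrogen-bond donors go from 2 to 1. No measurement at hand bears on the reason for this result. Still open, going by these compounds, is whether an amine or a carboxylic acid in place of either ring group at this carbon would move the number beyond the scatter.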